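A Phenyl Group Joins the Benzyl Arm of Compound 1

A few compounds are considered here, and "the series" means these few. Any claim that something is new, unique, unknown or untested is made for them only; others in the source may bear on it.

Compound 1 `Cc1ccc2[nH]c(-n3[nH]c(C)c(Cc4ccccc4)c3=O)nc2c1` is the reference point here. In an assay on isolated protein for inhibition of alpha-ketoglutarate-dependent dioxygenase alkB homolog 3 (Homo sapiens), read by polymerase chain reaction, with a stated time of 1 h (a higher number here means a weaker inhibitor, a lower number a stronger inhibitor), compound 1 gives 670 nM. Going by the values given here, its only measured companion is compound 2 `Cc1ccc2[nH]c(-n3[nH]c(C)c(Cc4ccccc4Cl)c3=O)nc2c1`, which carries chloro in place of hydrogen on an aromatic carbon; in this assay compound 2 gives 910 nM, so the two numbers sit within the scatter of each other, and the step of a 1.4-fold higher number from compound 1 to compound 2 (0.13 log units; within the scatter) is too small to read as a real change. Compound 3 `Cc1ccc2[nH]c(-n3[nH]c(C)c(Cc4ccc(-c5ccccc5)cc4)c3=O)nc2c1` has not been measured. It differs from compound 1 by phenyl in place of hydrogen on an aromatic carbon. Among the compounds with values here, the one step available, hydrogen to chloro, stayed within the scatter, and no measured pair speaks to a group of this size. The expectation is therefore a number near that of compound 1, with no step beyond the scatter: the expected step is a 1.0-fold higher number from compound 1 to compound 3 (0.02 log units; within the scatter). Compound 3 is estimated at 700 nM, within a range of 250 nM to 2000 nM.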

Compound 3, half-maximal inhibitory concentration: 5300 nM
Estimate against measurement, compound 3: 7.6-fold (0.88 log units) below; measured number above the stated range.
By their numbers in this assay, from the lowest: compounds 1 and 2 (each within the scatter of the next); then compound 3.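

Hydrogen to chloro in compound 2 stayed within the scatter, but phenyl on an aromatic carbon, para to a large group, does move the number in this assay: the step is a 7.9-fold higher number from compound 1 to compound 3 (0.90 log units; beyond the scatter), towards a weaker inhibitor. This shows that the ring at the end of the benzyl arm does not accept every added group without a loss, and that a change made on it can be read in this assay. No measurement shown explains why the phenyl group has this effect.

As far as these compounds go, whether a smaller group on the same carbon, such as methoxy or an amine, would keep the number near that of compound 1 remains open. So does whether a carboxylic acid there, or a phenyl group on another carbon of that ring, would give a step of similar size.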